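The source may hold more compounds than are shown below. What is called first, only, known or untested is meant among the compounds shown, and "the series" means these compounds.

Compound 1, `Cc1cc(O)cc(-c2nn(CC#N)cc2-c2ccnc(-c3ccc(Oc4ccccc4)cc3)c2)c1`: 2930 nM in a functional assay on SK-MEL-5 cells (Homo sapiens) for inhibition, read by sulforhodamine B assay, with a stated time of 48 h; on this read-out higher numbers stand for weaker inhibition of growth and lower numbers for stronger inhibition of growth
Compound 2, `COc1cc(C)cc(-c2nn(CC#N)cc2-c2ccnc(-c3ccc(N(C)C)cc3)c2)c1`: 269 nM in this assay

Of these two numbers, compound 2 has the lower one, and compound 1 stands clearly higher, a gap well beyond the usual scatter. Compound 1 and compound 2 differ in two places at once, so this gap cannot be assigned to either change on its own.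

Compound 3, `Cc1cc(O)cc(-c2nn(CC#N)cc2-c2ccnc(-c3ccc(N(C)C)cc3)c2)c1`, has not yet been measured. It differs from compound 2 in one place: hydrogen in place of methyl on an oxygen on an aromatic ring. Going by the values given here, no pair of measured compounds shows this change alone. Compound 1 carries the same hydroxy group and gives 2930 nM, but its other difference from compound 2 leaves that number uninformative here. A step of modest size is expected, more likely toward weaker growth inhibition than stronger, though a result within the scatter would not surprise. Compound 3 is expected to give about 450 nM, with a likely range from 150 nM to 1500 nM. The step this estimate implies is a 1.7-fold higher number from compound 2 to compound 3 (0.22 log units; within the scatter).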

Compound 3, concentration for 50% growth inhibition: 1990 nM
Estimate against measurement, compound 3: 4.4-fold (0.65 log units) below; measured number above the stated range.
By their numbers in this assay, from the lowest: compound 2; then compounds 3 and 1 (each within the scatter of the next).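

Removing the methyl from the oxygen, turning methoxy into hydroxy, gives a 7.4-fold higher number from compound 2 to compound 3 (0.87 log units; beyond the scatter) in this assay and so weakens growth inhibition beyond the scatter. This position is therefore sensitive to this small change, at least with the dimethylamino group in place. With the hydroxy group held constant, the other single change, from phenoxy to dimethylamino, gives a 1.5-fold lower number from compound 1 to compound 3 (0.17 log units; within the scatter) and stays within the scatter, so these two groups cannot be told apart in this setting. No measurement here explains why the methoxy and hydroxy compounds differ.

Going by these compounds alone, only one pair shows the methoxy to hydroxy change, so it remains open whether the step would be similar with phenoxy in place of dimethylamino. As far as these compounds go, how an ethoxy group or an amino group would compare with methoxy at this position also remains open.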